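A few compounds are considered here, and "the series" means these few. Any claim that something is new, unique, unknown or untested is made for them only; others in the source may bear on it.

Among the measured compounds shown here, in a functional assay on the whole organism for inhibition, with Cavia porcellus as the target (a lower number here means that less compound is needed, a higher number that more compound is needed for the effect), compound 2 (`CNC(=O)C1=CC(C)(C)Oc2ccc([N+](=O)[O-])cc21`) gives 33.1 nM, the only actual number available. Compound 1 (`CN(C)/C(=N\C#N)C1=CC(C)(C)Oc2ccc(Cl)cc21`) reaches only a limit of the assay, > 31600 nM. Compound 3 (`CN(C)C(=S)C1=CC(C)(C)Oc2ccc([N+](=O)[O-])cc21`) departs from compound 2 at one place: a group of 5 heavy atoms (3 carbon, 1 nitrogen, 1 sulfur; no ring) in place of a group of 4 heavy atoms (2 carbon, 1 nitrogen, 1 oxygen; no ring), on a double-bonded ring carbon. For the measured compounds named here, no measured pair shows what such an exchange does in this assay, so any forecast is uncertain. A loss of potency well beyond the scatter is nonetheless expected, with the methylcarbamoyl group and its hydrogen-bond donor gone. The estimated step is a 24-fold higher number from compound 2 to compound 3 (1.38 log units; beyond the scatter). For compound 3 the expected value is 800 nM, with an estimated range of 80 nM to 8000 nM.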

Compound 3, half-maximal effective concentration: 490 nM
Beside the measured number, compound 3's estimate is 1.6-fold (0.21 log units) above it; the measured number falls inside the stated range.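

In this assay, among the compounds shown here, the exchange of methylcarbamoyl for the sulfur-bearing group on the double-bonded ring carbon gives a 15-fold higher number from compound 2 to compound 3 (1.17 log units; beyond the scatter) and is the first readable step at this place. The position is therefore sensitive to this change, yet compound 3 still gives 490 nM with 0 hydrogen-bond donors in the entering group. Nothing shown here accounts for the size of this step. From the compounds shown here alone, what remains open is whether the sulfur or the added carbon carries the step. A dimethylcarbamoyl group or a carboxylic acid at this place would begin to separate these.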